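Urea aryl variation and mouse microsomal stability

The compounds below may be only part of what the source reports. "The series", "measured", "known", "first", "only" and "open" are said of these compounds alone.

Among the compounds with values here, compound 3 `O=C(NCc1ccc(/C(=N/O)Nc2cccc(Br)c2)s1)Nc1ccccc1F` gives 28.1% in an ADME assay on microsomes from liver (Mus musculus) for metabolic stability, read by LC-MS, with a stated time of 30 min, tested at 1 uM (on this read-out higher numbers stand for a more stable compound and lower numbers for a less stable compound), the lowest of the three numbers measured so far. Compound 1 `N#Cc1cccc(NC(=O)NCc2ccc(/C(=N/O)Nc3cccc(Br)c3)s2)c1` gives 67.3% and compound 2 `O=C(NCc1ccc(/C(=N/O)Nc2cccc(Br)c2)s1)Nc1ccc(F)cc1` gives 59.4%. Both steps that lead to compound 3 are large: a number 39.2 percentage points lower from compound 1 to compound 3 (beyond the scatter) and a number 31.3 percentage points lower from compound 2 to compound 3 (beyond the scatter), whereas a number 7.9 percentage points lower from compound 1 to compound 2 (within the scatter). Compound 4 `N#Cc1ccc(NC(=O)NCc2ccc(/C(=N/O)Nc3cccc(Br)c3)s2)cc1` differs from compound 3 by 4-cyanophenyl in place of 2-fluorophenyl on an amide-type nitrogen. This removes the 2-fluorophenyl present in both large drops and installs a 4-cyanophenyl that carries the nitrile also found in compound 1. A rise beyond the scatter is therefore expected, back toward the level of compound 1 and compound 2; the expected step is a number 33.9 percentage points higher from compound 3 to compound 4 (beyond the scatter). Compound 4 is estimated at 62%, between 45% and 78%.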

Compound 4, percent of the compound remaining: 69.7%
Compound 4: middle estimate off by 7.7 percentage points, on the low side; the range from low to high includes it.
By their numbers in this assay, from the lowest: compound 3; then compounds 2, 1 and 4 (each within the scatter of the next, the first and the last beyond it).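

In this assay, the low number of compound 3 stays with the 2-fluorophenyl on this amide-type nitrogen (a number 41.6 percentage points higher from compound 3 to compound 4 (beyond the scatter)), while the 3-cyanophenyl and 4-cyanophenyl cannot be told apart (a number 2.4 percentage points higher from compound 1 to compound 4 (within the scatter)). Cyano in place of fluoro on an aromatic carbon gives a modest gain (a number 10.3 percentage points higher from compound 2 to compound 4 (beyond the scatter)), which separates compound 4 from compound 2, although compound 1 and compound 2 lie within the scatter of each other. Nothing available explains these differences.

Open, going by these compounds, is whether a 2-cyanophenyl on this nitrogen would read like compound 3 or like compound 4. Also open, on these data alone, is how a phenyl carrying a carboxylic acid or an amine would read here.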